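Dropping a Methyl from the Amide Side Chain

This account rests on a few compounds, and the source may have more. Where it says the series, first, only, none or still open, it means among the compounds named here.

Measured compounds:
compound 1, `C[C@@H](NC(=O)c1ccc(C#Cc2cccc(F)c2)nc1)C(C)(C)O`, 64.9%
compound 2, `Cc1cc(C(=O)N[C@H](C)C(C)(C)O)ncc1C#Cc1cccc(F)c1`, 66.6%
compound 3, `C[C@H](NC(=O)c1ccc(C#Cc2cccc(F)c2)cn1)C(C)(C)C`, 70.8%

All three values come from a functional assay on HEK293 cells for positive allosteric modulation of metabotropic glutamate receptor 5 (Rattus norvegicus), read by fluorescence and calcium flux; on this read-out higher numbers stand for larger maximal responses and lower numbers for smaller maximal responses. In this assay compound 1 gives 64.9%, compound 2 gives 66.6% and compound 3 gives 70.8%. Compound 3 has the highest number of the three, but its distance to compound 2 and its distance to compound 1 both lie within the usual scatter of repeated measurements, so the three compounds cannot be placed in an order on this read-out. The three share the same two-ring core joined through a triple bond and differ in the side chain that hangs on the amide nitrogen and in the placement of the ring nitrogen.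

The next compound, compound 4, `CC(C)(C)CNC(=O)c1ccc(C#Cc2cccc(F)c2)cn1`, is a close relative of compound 3. The change is this: hydrogen in place of methyl on a saturated chain carbon bound to an amide-type nitrogen and a saturated chain carbon. Among the measured compounds shown here, nothing measured so far isolates this kind of change, so the expectation rests on the three values alone, which sit close together despite differing side chains. In this assay the step from compound 3 to compound 4 is expected to be small, a number 2.8 percentage points lower from compound 3 to compound 4 (within the scatter), not beyond the scatter in either direction. Compound 4 is therefore estimated at 68%, with a range from 52% to 84%.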

Compound 4, largest response reached (reported as efficacy), in percent of the reference or control that the assay uses: 63.9%
For compound 4 the middle estimate is 4.1 percentage points above the measured one; the range from low to high includes it.
By their numbers in this assay, from the lowest: compounds 4, 1, 2 and 3 (each within the scatter of the next).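

Among the compounds shown here, compound 3 and compound 4 are the first pair here that differ in one place only, the 1,2,2-trimethylpropyl group becoming neopentyl, and in this assay the swap reads a number 6.9 percentage points lower from compound 3 to compound 4 (within the scatter). This shows that on a saturated chain carbon bound to an amide-type nitrogen and a saturated chain carbon, hydrogen can stand in place of methyl without a step beyond the usual scatter, so in this pair the largest response does not visibly depend on that methyl. No separate information is available that could explain the size of this step or connect it to any property of the two side chains.

As far as these compounds go, whether the same swap would give a similarly small step on a different side chain or with the ring nitrogen placed differently remains open, as one pair cannot establish a general rule. Also open, from the compounds shown here alone, is what an ethyl group, a longer chain, an amine or a carboxylic acid on this same carbon would give in place of the methyl, and whether any of these would move the largest response beyond the scatter.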